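The compounds below may be only part of what the source reports. "The series", "measured", "known", "first", "only" and "open" are said of these compounds alone.

Working notes on the series. Compound 1 `c1ccc(-c2cn3ccnc3c(-c3ccc4ncn(C5CCCCC5)c4c3)n2)cc1` gives 39.8% in a functional assay on SF-295 cells (Homo sapiens) for inhibition, read by sulforhodamine B assay, with a stated time of 48 h, tested at 10 uM; a lower number here means less inhibition, a higher number more inhibition at the concentration tested (going by the name of the read-out). Compound 2 `c1ccc2c(-c3cn4ccnc4c(-c4ccc5ncn(C6CCCCC6)c5c4)n3)cccc2c1` gives 6.34%, and compound 3 `COc1ccccc1-c1cn2ccnc2c(-c2ccc3ncn(C4CCCCC4)c3c2)n1` gives 9.76%; compound 3 thus holds the second of the three numbers, within the scatter of compound 2 and well below compound 1. The measured steps are a number 33.5 percentage points lower from compound 1 to compound 2 (beyond the scatter) and a number 3.4 percentage points higher from compound 2 to compound 3 (within the scatter). Compound 4 `Fc1ccccc1-c1cn2ccnc2c(-c2ccc3ncn(C4CCCCC4)c3c2)n1` differs from compound 3 by fluoro in place of methoxy on an aromatic carbon. Within the data shown here, no measured step exchanges methoxy for fluoro; the nearest guide is a number 30 percentage points lower from compound 1 to compound 3 (beyond the scatter), which compound 4 partly undoes in structure, though compound 2 shows that a different group in place of phenyl also gave a low number. A modest upward step is expected, a number 10.2 percentage points higher from compound 3 to compound 4 (beyond the scatter). For compound 4 in this assay the estimate is 20%, with a range from 5% to 42%.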

Compound 4, a percentage reported as inhibition, at one concentration (the size of the read-out at that concentration, not a potency): 10.4%
For compound 4 the middle estimate is 9.6 percentage points above the measured one; the measured number falls inside the stated range.
By their numbers in this assay, from the lowest: compounds 2, 3 and 4 (each within the scatter of the next); then compound 1.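

In this assay, the smallest group at this place, ortho to a large group, does not restore the number of the unsubstituted phenyl: fluoro in place of hydrogen gives a number 29.4 percentage points lower from compound 1 to compound 4 (beyond the scatter) and remains low. Fluoro in place of methoxy gives a number 0.6 percentage points higher from compound 3 to compound 4 (within the scatter) and 2-fluorophenyl in place of naphthalen-1-yl gives a number 4.1 percentage points higher from compound 2 to compound 4 (within the scatter), so these three substituted compounds cannot be told apart. No evidence on the cause of this is available. On these data alone, it remains open whether an amine or a hydroxyl group at this place would differ from fluoro, and whether any substituent here can match compound 1.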